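Benzyl for Difluorophenyl at the Cytotoxicity Limit

The source may hold more compounds than are shown below. What is called first, only, known or untested is meant among the compounds shown, and "the series" means these compounds.

Compound 1, `Cc1ccccc1CNc1nn(-c2ccc(F)cc2F)cc1CNCCN1CCN(C)CC1`, gives > 20000 nM.
Compound 2, `Cc1ccccc1-c1nn(-c2ccc(F)c(F)c2)cc1CNCCN1CCN(C)CC1`, gives > 20000 nM.
Compound 3, `Cc1ccccc1-c1nn(-c2ccc(F)cc2F)cc1CNCCN1CCN(C)CC1`, gives > 20000 nM.

All three of these values are limits of an ADME assay on Huh-7 cells (Homo sapiens) for cytotoxicity (a higher number here means that more compound is tolerated, a lower number that less compound is tolerated), not numbers. For compound 3 the value in this assay is only such a limit, as are the other two values shown, so that the limit of > 20000 nM in this assay, at which 3 of the 3 values shown sit, describes the whole set. The change to compound 4, `Cc1ccccc1-c1nn(Cc2ccccc2)cc1CNCCN1CCN(C)CC1`, is benzyl in place of 2,4-difluorophenyl on an aromatic nitrogen. The two measured steps that touch compound 3 are a step that the two limits leave unreadable from compound 1 to compound 3 and a step that the two limits leave unreadable from compound 2 to compound 3; neither resolves into a readable size, and neither involves a benzyl group. The expectation for the step is therefore a step that the limit leaves unreadable from compound 3 to compound 4, with no movement beyond the scatter. Compound 4 is estimated at 30000 nM, within 15000 nM to 80000 nM, most likely again reported as a limit.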

Compound 4, half-maximal cytotoxic concentration: > 20000 nM
Compound 4 gave a limit, no number (the forecaster's own chance of this, stated with the estimate: 85%); the middle value is on the limit's open side.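

Among the compounds shown here, compound 4 gives > 20000 nM in this assay, which is a limit, so no step from compound 2 or compound 3 to compound 4 can be read. The compounds shown leave open what concentration of any of them is actually cytotoxic, and whether the benzyl group changes it.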